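This account rests on a few compounds, and the source may have more. Where it says the series, first, only, none or still open, it means among the compounds named here.

Compound 3 `Cc1cc(Br)cn2c(CSCCc3ccccc3)cnc12` carries a bromo group on the shared core. In an ADME assay on HEL cells (Homo sapiens) for cytotoxicity, with a stated time of 3 days (on this read-out lower numbers stand for higher toxicity in this test and higher numbers for lower toxicity in this test), compound 3 gives >= 2 ug/mL, which is a limit of the assay and not a number. Two relatives with an aryl group on the same core have also been tested. Compound 1 `COc1cccc(-c2cc(C)c3ncc(CSCCc4ccccc4)n3c2)c1` gives 20 ug/mL in this assay. Compound 2 `Cc1cc(-c2ccc(C#N)cc2)cn2c(CSCCc3ccccc3)cnc12` gives >= 20 ug/mL in this assay, and this too is a limit. The steps among the three are therefore hard to read: a number no lower from compound 1 to compound 2 (the limit leaves the size open), a step that the limit leaves unreadable from compound 1 to compound 3 and a step that the two limits leave unreadable from compound 2 to compound 3; the values in question stand at the limit of >= 2 ug/mL in this assay, at which 1 of the 3 values shown sits, and (the limit of >= 20 ug/mL in this assay, at which 1 of the 3 values shown sits). Compound 4 `Cc1cc(-c2ccccc2O)cn2c(CSCCc3ccccc3)cnc12` has not yet been measured. It differs from compound 3 by 2-hydroxyphenyl in place of bromo on an aromatic carbon. The steps from compound 1 to compound 3 and from compound 2 to compound 3 bear on this change, each swapping an aryl group on the same carbon for bromo, yet neither has a readable size. Compound 1 at 20 ug/mL is the only aryl relative with a number. Compound 4 is expected to sit in that same region, with an expected step that the limit leaves unreadable from compound 3 to compound 4 that the limit on compound 3 leaves open. The estimate for compound 4 in this assay is 20 ug/mL, between 7 ug/mL and 60 ug/mL.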

Compound 4, minimum cytotoxic concentration: 100 ug/mL
Estimate against measurement, compound 4: 5.0-fold (0.70 log units) below; measured number outside the range, above it.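

In this assay, the two aryl groups compared on this aromatic carbon do not behave alike: 2-hydroxyphenyl in place of 3-methoxyphenyl gives a 5.0-fold higher number from compound 1 to compound 4 (0.70 log units; beyond the scatter). Among these compounds, this is the first step of readable size, and it shows that the read-out at this position, two atoms from the ring nitrogen, depends on which aryl group is attached and not merely on an aryl group being present. The steps to compound 4 from compound 2 and from compound 3 cannot be read, as the values of both of those compounds are limits and not numbers, so neither the comparison with bromo nor the one with 4-cyanophenyl has a size.

Among the compounds shown here, nothing measured here accounts for the higher number with 2-hydroxyphenyl, and the single readable step cannot separate the effect of the hydroxy group from that of where it sits on the aryl ring. As far as these compounds go, it also remains open how this read-out would respond to an aminophenyl group or to a phenyl ring carrying a carboxylic acid at this same carbon.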